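The compounds below may be only part of what the source reports. "The series", "measured", "known", "first", "only" and "open" are said of these compounds alone.

Measured in a physicochemical assay for metabolic stability, read by HPLC and mass spectrometry, in phosphate buffer, at 37 degrees C, at pH 7.4; a higher number here means that the compound lasts longer, a lower number that the compound disappears faster:
- Compound 1 `CC(C)(O/N=C(\C(=O)N[C@@H]1C(=O)N(S(=O)(=O)O)[C@@H]1CN1CCCC1=O)c1csc(N)n1)C(=O)O`: > 1000 h, a limit of the assay
- Compound 2 `CC(C)(O/N=C(\C(=O)N[C@@H]1C(=O)N(S(=O)(=O)O)[C@@H]1Cn1ccnn1)c1csc(N)n1)C(=O)O`: 257 h
- Compound 3 `CC(C)(O/N=C(\C(=O)N[C@@H]1C(=O)N(S(=O)(=O)O)[C@@H]1Cn1cncn1)c1csc(N)n1)C(=O)O`: 233 h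

Compound 3 stands at the low end of these numbers, level with its triazole partner: a 1.1-fold lower number from compound 2 to compound 3 (0.04 log units; within the scatter). Compound 4 `C[C@@H]1CN(C[C@@H]2[C@H](NC(=O)/C(=N\OC(C)(C)C(=O)O)c3csc(N)n3)C(=O)N2S(=O)(=O)O)C(=O)O1` keeps the shared core and changes one group, 5-methyl-2-oxo-1,3-oxazolidin-3-yl in place of 1H-1,2,4-triazol-1-yl on a saturated chain carbon bound to a saturated ring carbon: 5-methyl-2-oxo-1,3-oxazolidin-3-yl replaces 1H-1,2,4-triazol-1-yl on a saturated chain carbon bound to a saturated ring carbon. The entering group is a five-membered non-aromatic ring, closer by name to the 2-oxopyrrolidin-1-yl of compound 1 than to either triazole. Among the compounds with values here, the steps that bear on this are an at least 4.2-fold lower number from compound 1 to compound 3 (0.63 log units; beyond the scatter) and an at least 3.8-fold lower number from compound 1 to compound 2 (0.59 log units; beyond the scatter), which are similar in size. Both start from the limit of compound 1. A rise of comparable size, in the reverse direction, is therefore expected. The estimated step is a 3.0-fold higher number from compound 3 to compound 4 (0.48 log units; beyond the scatter). Compound 4 is expected at 700 h, with an estimated range of 250 h to 2000 h.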

Compound 4, half-life: > 37 h
Compound 4: no number, only a limit; the forecaster's own chance of this, stated with the estimate: 40%; the middle value is on the limit's open side.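

In this assay, within the data shown here, compound 4 gives > 37 h, which is a limit, so no step linking compound 4 to compound 1, compound 2 or compound 3 can be read. The compounds shown leave open how long compound 4 actually lasts.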